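From fluoro to hydroxy: the step to compound 4

The compounds below may be only part of what the source reports. "The series", "measured", "known", "first", "only" and "open" are said of these compounds alone.

Measured in a functional assay on MCF7 cells (Homo sapiens) for inhibition, read by sulforhodamine B assay; on this read-out higher numbers stand for weaker inhibition of growth and lower numbers for stronger inhibition of growth:
- compound 1 `COc1cc(-c2ccc(-c3ccc(-c4nc5cc(C)ccc5[nH]4)cc3)cc2)cc(OC)c1OC`: 170 nM
- compound 2 `Fc1ccc(-c2ccc(-c3ccc(-c4nc5ccccc5[nH]4)cc3)cc2)cc1`: 36200 nM
- compound 3 `Oc1cccc2[nH]c(-c3ccc(-c4ccc(-c5ccc(F)cc5)cc4)cc3)nc12`: 3010 nM

Among the measured compounds shown here, of these three numbers, the one for compound 3 is the second highest, with compound 2 higher and compound 1 lower. Compound 4 `Oc1ccc(-c2ccc(-c3ccc(-c4nc5c(O)cccc5[nH]4)cc3)cc2)cc1` follows from compound 3 by one change, hydroxy in place of fluoro on an aromatic carbon, 4-fluorophenyl to 4-hydroxyphenyl. For the measured compounds named here, only one measured step bears on this, and only indirectly: a 12-fold lower number from compound 2 to compound 3 (1.08 log units; beyond the scatter), where hydroxy replaced hydrogen at another place. A smaller step in the same direction is therefore expected, a 2.5-fold lower number from compound 3 to compound 4 (0.40 log units; beyond the scatter). Compound 4 is estimated at 1200 nM, with an expected range of 250 nM to 6000 nM.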

Compound 4, concentration for 50% growth inhibition: 190 nM
Beside the measured number, compound 4's estimate is 6.3-fold (0.80 log units) above it; the whole stated range lies above it.
By their numbers in this assay, from the lowest: compounds 1 and 4 (each within the scatter of the next); then compound 3; then compound 2.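

In this assay, among the compounds shown here, the earlier compounds showed a hydroxy gain only at another place, with a step of a 12-fold lower number from compound 2 to compound 3 (1.08 log units; beyond the scatter) on that change. The 4-fluorophenyl to 4-hydroxyphenyl change now gives a 16-fold lower number from compound 3 to compound 4 (1.20 log units; beyond the scatter) and so shows that this position, para to a large group, also responds strongly to the group it carries. Nothing measured here accounts for the size of this step.

On these data alone, whether an amine or a carboxylic acid at this position would give a similar number stays open. So does whether the 4-hydroxyphenyl group would give such a step without the other hydroxy.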